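This account rests on a few compounds, and the source may have more. Where it says the series, first, only, none or still open, it means among the compounds named here.

Measured compounds:
Compound 1 `Cc1c(C)c2c(c(C)c1O)CCC(C)(C(=O)NCCN(C)C)O2` gives 8700 nM in a functional assay (brain) for inhibition, with Rattus norvegicus as the target; a lower number here means a stronger inhibitor, a higher number a weaker inhibitor.
Compound 2 `CCN(CC)c1ccc(N2CCN(CC3(C)CCc4c(C)c(O)c(C)c(C)c4O3)CC2)nc1N(CC)CC` gives 1000 nM in this assay.
Compound 3 `Cc1c(C)c2c(c(C)c1O)CCC(C)(CN1CCCC1)O2` gives 1400 nM in this assay.

Among these three numbers compound 3 stands second highest. Its nearest neighbour is compound 2, whose number is lower by a gap that lies within the scatter, so the two cannot be ordered. The furthest is compound 1, whose number is higher by a gap beyond the scatter; compound 1 is thus the weaker inhibitor of the pair. Compound 4 `Cc1c(C)c2c(c(C)c1O)CCC(C)(CNCCN(C)C)O2` has not yet been measured in this assay. It differs from compound 3 in one place: (2-(dimethylamino)ethyl)amino in place of pyrrolidin-1-yl on a saturated chain carbon bound to a saturated ring carbon. The shared core of compound 3 and compound 4 is kept. Within the data shown here, no step between two measured compounds matches this change, so its size is open. Given that compound 1, which also carries a (dimethylamino)ethyl group on its side chain, gives 8700 nM, a mild move toward a higher number is expected for compound 4, roughly a 1.6-fold higher number from compound 3 to compound 4 (0.20 log units; within the scatter), possibly not beyond the scatter. Compound 4 is estimated at 2200 nM, with a likely range from 700 nM to 7000 nM.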

Compound 4, half-maximal inhibitory concentration: 1700 nM
Beside the measured number, compound 4's estimate is 1.3-fold (0.11 log units) above it; measured number inside the range.
By their numbers in this assay, from the lowest: compounds 2, 3 and 4 (each within the scatter of the next); then compound 1.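

In this assay putting (2-(dimethylamino)ethyl)amino in place of pyrrolidin-1-yl on a saturated chain carbon bound to a saturated ring carbon gives a 1.2-fold higher number from compound 3 to compound 4 (0.08 log units; within the scatter) and so compound 3 and compound 4 cannot be ordered. At this position, then, the five-membered non-aromatic ring can give way to an open chain with a second nitrogen and a hydrogen-bond donor, and the number stays within the scatter. No measurement at hand accounts for the two groups reading alike.

The compounds shown leave open whether any nitrogen is needed on this chain carbon, which a hydroxyl group or a methoxy group there would test. They also leave open how far the amine can grow, for instance to a piperidin-1-yl ring or a longer chain ending in dimethylamino.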